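One Methyl More on Compound 2

The compounds below may be only part of what the source reports. "The series", "measured", "known", "first", "only" and "open" are said of these compounds alone.

Compound 1 `O=S(=O)(Nc1ccc(-c2nc3cc(NS(=O)(=O)c4ccccc4O)ccc3o2)cc1)c1ccccc1O` gives 18000 nM.
Compound 2 `Cc1ccc(S(=O)(=O)Nc2ccc(-c3nc4ccccc4o3)cc2)cc1` gives only a limit of the assay, > 100000 nM.
Compound 3 `O=S(=O)(Nc1ccc2oc(-c3ccccc3)nc2c1)c1cccc(F)c1` also gives only a limit of the assay, > 100000 nM.

These three values come from an assay on cells for inhibition of HSP60/HSP10 (Homo sapiens), with a stated time of 60 min; a lower number here means a stronger inhibitor, a higher number a weaker inhibitor. Compound 1 is the only one of the three with a number. Compound 2 stands at a limit of the assay, and it is not alone there, since (the limit of > 100000 nM in this assay, at which 2 of the 3 values shown sit). Compound 3 sits at that same limit. For the measured compounds named here, no pair among the three differs in one place, so no measured step exists to lean on.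

Compound 4 `CCc1ccc(S(=O)(=O)Nc2ccc(-c3nc4ccccc4o3)cc2)cc1` is the not yet measured partner of compound 2. The change is methyl in place of hydrogen on a saturated chain carbon bound to an aromatic carbon. Compound 4 thus carries an ethyl where compound 2 carries a methyl, and nothing else in the structure moves.

Because compound 2 shows > 100000 nM, the starting point is a limit rather than a number, and a change of one carbon on a saturated chain carbon gives no reason to expect the result to come down into the measurable range. The step from compound 2 to compound 4 is expected to be a step that the limit leaves unreadable from compound 2 to compound 4, that is, none beyond the scatter. Compound 4 is therefore estimated at 150000 nM, with a range from 40000 nM to 600000 nM, most likely reported again as a limit.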

Compound 4, half-maximal inhibitory concentration: > 100000 nM
Compound 4 ended at the assay's limit; the forecaster's own chance of this, stated with the estimate: 80%; the middle value lies beyond the limit too.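

Compound 4 gives > 100000 nM, which is a limit of the assay and not a number. Compound 2 sits at a limit as well, so no step can be read between compound 2 and compound 4. The compounds shown leave open whether going from methyl to ethyl changes inhibition at all, as neither compound carries a number.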